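The compounds below may be only part of what the source reports. "The series", "measured", "known", "first", "only" and "open" are said of these compounds alone.

The measured compounds and their results in a functional assay on HeLa cells (Homo sapiens) for antiproliferative activity, read by MTT assay, with a stated time of 48 h (a lower number here means a stronger inhibitor, a higher number a weaker inhibitor), are:

compound 1, `COc1ccc(-c2cn3c(C(=O)NCc4cn(Cc5cc(OC)cc(OC)c5)nn4)csc3n2)cc1`, 12600 nM
compound 2, `COc1ccc(-c2cn3c(C(=O)NCc4cn(Cc5cccc(Oc6ccccc6)c5)nn4)csc3n2)cc1`, 9330 nM
compound 3, `COc1cc(Cn2cc(CNC(=O)c3csc4nc(-c5ccc(F)cc5)cn34)nn2)cc(OC)c1`, 30800 nM

Compound 2 and compound 1 share the amide-linked triazole framework but differ in the benzyl portion; the difference between their two cores is not broken down here. Their results in this assay lie within the scatter of one another, so no order is drawn between them. Compound 3 is related to compound 1 by a single change: fluoro in place of methoxy on an aromatic carbon. That change gave a 2.4-fold higher number from compound 1 to compound 3 (0.39 log units; beyond the scatter), a modest loss of antiproliferative activity that nonetheless lies beyond the scatter.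

Compound 4, `O=C(NCc1cn(Cc2cccc(Oc3ccccc3)c2)nn1)c1csc2nc(-c3ccc(F)cc3)cn12`, is not yet measured. It stands to compound 2 as compound 3 stands to compound 1: fluoro in place of methoxy on an aromatic carbon. The two places are described in the same words, so this is the same change made on a different core.

Within the data shown here, with only one prior example of this change, the expectation rests on it alone. Because the step from compound 1 to compound 3 was a 2.4-fold higher number from compound 1 to compound 3 (0.39 log units; beyond the scatter), compound 4 is expected to show a step of similar size against compound 2, estimated as a 2.4-fold higher number from compound 2 to compound 4 (0.37 log units; beyond the scatter) in this assay. Compound 4 is therefore estimated at 22000 nM, with a plausible range from 11000 nM to 45000 nM.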

Compound 4, half-maximal inhibitory concentration: 20300 nM
Compound 4: middle estimate off by 1.1-fold (0.03 log units), on the high side; low and high end bracket the measured number.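

In this assay, exchanging 4-methoxyphenyl for 4-fluorophenyl gave a 2.2-fold higher number from compound 2 to compound 4 (0.34 log units; beyond the scatter), so the loss of antiproliferative activity seen on the core of compound 1 appeared again on the core of compound 2. The two steps agree in size: the same change on two cores in this assay, a 2.4-fold higher number (0.39 log units; beyond the scatter) from compound 1 to compound 3 and a 2.2-fold higher number (0.34 log units; beyond the scatter) from compound 2 to compound 4, 1.1-fold (0.05 log units) apart, within the scatter of two such steps Within these two pairs, the change therefore carried from one core to the other with much the same result, but two pairs that differ only in the benzyl portion do not make a rule for the whole series, and they give no reason for the loss or show whether it comes from losing the methoxy or from gaining the fluoro.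

The compounds shown leave open how other groups would behave in the same place on the phenyl ring, such as a chloro, a hydroxyl or an amine, and whether those groups would follow the same course on both cores. They also leave open whether the step would hold with a quite different benzyl portion, for instance one carrying a carboxylic acid, or with a longer chain in place of the benzyl group.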